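This account rests on a few compounds, and the source may have more. Where it says the series, first, only, none or still open, it means among the compounds named here.

Measured in a functional assay on NCI-H23 cells (Homo sapiens) for inhibition, read by sulforhodamine B assay, with a stated time of 48 h; a lower number here means a stronger inhibitor of growth, a higher number a weaker inhibitor of growth:
- compound 1 `O=C(Cc1csc2nc(-c3ccc(Br)cc3)cn12)N/N=C/c1ccccc1`: 12600 nM
- compound 2 `O=C(Cc1csc2nc(-c3ccc(Br)cc3)cn12)N/N=C/c1ccccc1O`: 3390 nM
- compound 3 `COc1cccc(OC)c1/C=N/NC(=O)Cc1csc2nc(-c3ccc(Br)cc3)cn12`: 19500 nM

Compound 3 shares the high end of these numbers with compound 1, and the two lie within the scatter of each other: a 1.5-fold higher number from compound 1 to compound 3 (0.19 log units; within the scatter). The clear gap is to compound 2: a 5.8-fold higher number from compound 2 to compound 3 (0.76 log units; beyond the scatter).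

The next compound, compound 4 `O=C(Cc1csc2nc(-c3ccc(Br)cc3)cn12)N/N=C/c1ccc(Cl)cc1Cl`, keeps the shared core and has 2,4-dichlorophenyl in place of 2,6-dimethoxyphenyl on a carbon with a double bond to nitrogen.

All three measured steps concern this same part of the molecule. The one clear drop, a 3.7-fold lower number from compound 1 to compound 2 (0.57 log units; beyond the scatter), came with a hydroxy group, which compound 4 does not carry. For the measured compounds named here, no measured compound carries chlorine, so the data offer no direct guide. Compound 4 is therefore expected to lie nearer compound 1, at 12600 nM, than the hydroxy compound.

The expected change is small, a 2.2-fold lower number from compound 3 to compound 4 (0.34 log units; beyond the scatter). For compound 4 the estimated value is 9000 nM, with an expected range of 3000 nM to 25000 nM.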

Compound 4, concentration for 50% growth inhibition: 25700 nM
Estimate against measurement, compound 4: 2.9-fold (0.46 log units) below, outside the stated range (above it).
By their numbers in this assay, from the lowest: compound 2; then compounds 1, 3 and 4 (each within the scatter of the next, the first and the last beyond it).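

Adding chlorine to this ring brings no gain in growth inhibition. The 2,4-dichlorophenyl group cannot be told apart from the 2,6-dimethoxyphenyl group at this place (a 1.3-fold higher number from compound 3 to compound 4 (0.12 log units; within the scatter)), yet it gives a higher number than plain phenyl (a 2.0-fold higher number from compound 1 to compound 4 (0.31 log units; beyond the scatter)) and stands further still from the 2-hydroxyphenyl group (a 7.6-fold higher number from compound 2 to compound 4 (0.88 log units; beyond the scatter)). For the compounds shown here, compound 2 thus remains the only compound here with a number clearly lower than that of unsubstituted compound 1, and no supporting measurement is available to explain these differences.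

The compounds shown leave open whether a single chlorine would behave as the two chlorines do. They also leave open whether an amine or a carboxylic acid on this ring would match or pass the hydroxy group of compound 2.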